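Cinnamamide analogues of a trimethoxybenzophenone: expected potency of compound 4

The source may hold more compounds than are shown below. What is called first, only, known or untested is meant among the compounds shown, and "the series" means these compounds.

Measured compounds and their values in a functional assay on B16 cells (Mus musculus) for cytotoxicity, read by MTT assay, with a stated time of 72 h; on this read-out higher numbers stand for weaker inhibition and lower numbers for stronger inhibition:
compound 1, `COc1ccc(C(=O)c2cc(OC)c(OC)c(OC)c2)cc1N`, 30 nM
compound 2, `COc1ccc(C(=O)c2cc(OC)c(OC)c(OC)c2)cc1NC(=O)/C=C/c1ccc(F)c(F)c1`, 6500 nM
compound 3, `COc1ccc(/C=C/C(=O)Nc2cc(C(=O)c3cc(OC)c(OC)c(OC)c3)cc(OC)c2OC)cc1OC`, 1300 nM

Compound 3 holds the second highest of the three numbers in this assay. Its nearest neighbour is compound 2, which gives a higher number, and the gap between them is beyond the scatter. The furthest is compound 1, the free amine, which gives a far lower number; that gap also lies beyond the scatter. Both acylated compounds thus sit well above the amine, and among them the difluorophenyl cinnamamide of compound 2 carries the higher number, though it also sits on a different core, so the two values only show that fluorinated cinnamamides on these cores have given weaker inhibition.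

Compound 4, `COc1cc(C(=O)c2cc(OC)c(OC)c(OC)c2)cc(NC(=O)/C=C/c2ccc(F)cc2)c1OC`, keeps the core of compound 3 and changes the cinnamamide: 4-fluorophenyl in place of 3,4-dimethoxyphenyl on a double-bonded chain carbon bound to a double-bonded chain carbon. Among the measured compounds shown here, no measured pair isolates this change. The only fluorinated comparator, compound 2, gives 6500 nM on another core. The step from compound 3 to compound 4 is therefore expected to be a modest rise in the number, a 1.9-fold higher number from compound 3 to compound 4 (0.28 log units; within the scatter), possibly within the scatter. Compound 4 is expected to give 2500 nM in this assay, with a range of 800 nM to 8000 nM.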

Compound 4, half-maximal inhibitory concentration: 900 nM
Compound 4: the middle estimate sits 2.8-fold (0.44 log units) above what was measured; measured number inside the range.
By their numbers in this assay, from the lowest: compound 1; then compounds 4 and 3 (each within the scatter of the next); then compound 2.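

In this assay, among the compounds shown here, 4-fluorophenyl in place of 3,4-dimethoxyphenyl on a double-bonded chain carbon bound to a double-bonded chain carbon gives a 1.4-fold lower number from compound 3 to compound 4 (0.16 log units; within the scatter), the first reading of a change confined to this position. On this core, the read-out therefore cannot tell the two aryl groups apart, although they differ in heavy atoms and hydrogen-bond acceptors, and neither the two methoxy groups nor the fluorine is shown to set the value here. No supporting measurement is available that bears on why the two compounds read alike.

The compounds shown leave open whether any group at this position moves the number beyond the scatter, for instance an unsubstituted phenyl, a 4-aminophenyl or a 4-carboxyphenyl, or a saturated propanamide chain in place of the double-bonded one. They also leave open whether the same exchange of aryl groups reads alike on the core of compound 2, and what a free amine on the core of compound 3 would give.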